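The compounds below may be only part of what the source reports. "The series", "measured", "known", "first", "only" and "open" are said of these compounds alone.

Measured in a functional assay on SMMC-7721 cells (Homo sapiens) for antiproliferative activity, read by MTT assay, with a stated time of 48 h; on this read-out higher numbers stand for weaker inhibition and lower numbers for stronger inhibition:
- compound 1 `CCN(CC)C/C1=C/C[C@](C)(CCC=C(C)C)/C=C/[C@@H](OC(=O)C=C(C)C)[C@](C)(O)/C=C/C1=O`: 570 nM
- compound 2 `CC(C)=CCC[C@]1(C)/C=C/[C@@H](OC(=O)C=C(C)C)[C@](C)(O)/C=C/C(=O)/C(CN(C(C)C)C(C)C)=C\C1`: 340 nM

For the measured compounds named here, compound 2 stands at 340 nM, with compound 1 as its only neighbour, and the two cannot be separated: a 1.7-fold lower number from compound 1 to compound 2 (0.22 log units; within the scatter). Compound 3 `CC[Si](CC)(CC)C/C1=C/C[C@](C)(CCC=C(C)C)/C=C/[C@@H](OC(=O)C=C(C)C)[C@](C)(O)/C=C/C1=O` follows from compound 2 by one change, on a saturated chain carbon bound to a double-bonded ring carbon: a group of 7 heavy atoms (6 carbon, 1 silicon; no ring) in place of a group of 7 heavy atoms (6 carbon, 1 nitrogen; no ring), on a saturated chain carbon bound to a double-bonded ring carbon. The diisopropylamino group leaves, and the entering group has no common name. Going by the values given here, only one measured step bears on this, and it exchanges one amino group for another, so the series holds no measurement of a group without nitrogen at this place. The step seen with compound 2, a 1.7-fold lower number from compound 1 to compound 2 (0.22 log units; within the scatter), therefore gives only a weak guide. A moderately higher number is expected in this assay, with low confidence. The expected step is a 2.6-fold higher number from compound 2 to compound 3 (0.42 log units; beyond the scatter). Compound 3 is estimated at 900 nM, with an expected range of 200 nM to 4000 nM.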

Compound 3, half-maximal inhibitory concentration: 3460 nM
Estimate against measurement, compound 3: 3.8-fold (0.58 log units) below; the measured number falls inside the stated range.
By their numbers in this assay, from the lowest: compounds 2 and 1 (each within the scatter of the next); then compound 3.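

In this assay, for the compounds shown here, the amino groups of the earlier compounds could not be separated, but leaving nitrogen at this place does register: the silicon-bearing group gives a 10-fold higher number from compound 2 to compound 3 (1.01 log units; beyond the scatter) in place of diisopropylamino and a 6.1-fold higher number from compound 1 to compound 3 (0.78 log units; beyond the scatter) in place of diethylamino. So the saturated chain carbon bound to a double-bonded ring carbon is not indifferent to the group it carries, and against diisopropylamino the step comes with the heavy-atom count unchanged at 7, while hydrogen-bond acceptors go from 1 to 0. No measurement here accounts for the step.

Open, on these data alone, is whether the silicon atom itself matters, which a matching all-carbon group with a central carbon would test. Also open, as far as these compounds go, is whether a cyclic amine such as piperidine or morpholine would stay level with the two open-chain amines.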